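Purine series: cyclohexyl in place of 4-methylphenyl

The source may hold more compounds than are shown below. What is called first, only, known or untested is meant among the compounds shown, and "the series" means these compounds.

Values so far in a functional assay on HepG2 cells (Homo sapiens) for antiproliferative activity, read by CCK-8 assay, with a stated time of 72 h, tested at 2 uM; a higher number here means a stronger effect of the compound at the concentration tested, a lower number a weaker effect:
Compound 1 `Cc1ccc(Nc2nc(Cl)nc3c2ncn3Cc2ccc(C(=O)Nc3ccccc3N)cc2)cc1` gives 76.2%.
Compound 2 `Cc1ccc(Nc2nc(Cl)nc3c2ncn3Cc2ccc(/C=C/C(=O)Nc3ccccc3N)cc2)cc1` gives 33.6%.
Compound 3 `Nc1ccccc1NC(=O)c1ccc(Cn2cnc3c(Nc4cccc(OC(F)(F)F)c4)nc(Cl)nc32)cc1` gives 1.88%.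

Compound 2 stands second highest of the three numbers. Compound 1 sits above it by the step of a number 42.6 percentage points lower from compound 1 to compound 2 (beyond the scatter), a change in the linker to the benzamide. Going by the values given here, compound 3 sits below compound 2, beyond the scatter; no single-point step connects these two.

Compound 4 `Nc1ccccc1NC(=O)/C=C/c1ccc(Cn2cnc3c(NC4CCCCC4)nc(Cl)nc32)cc1` is the next member, differing from compound 2 by cyclohexyl in place of 4-methylphenyl on a nitrogen on an aromatic ring. Among the compounds with values here, the only measured step touching this nitrogen is a number 74.3 percentage points lower from compound 1 to compound 3 (beyond the scatter), where one aromatic substituent replaced another on the shorter-linker parent and the number fell sharply. Nothing measured places a non-aromatic ring on this nitrogen, so the direction rests on that one step alone. Since compound 2 already sits in the middle of the scale, the room for a fall is bounded by zero. A decrease is expected, a number 21.6 percentage points lower from compound 2 to compound 4 (beyond the scatter), on the basis of the sensitivity seen in a number 74.3 percentage points lower from compound 1 to compound 3 (beyond the scatter). For compound 4 the expected value is 12%, with a range from 0% to 35%.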

Compound 4, a percentage reported as inhibition, at one concentration (the size of the read-out at that concentration, not a potency): 3.83%
Estimate against measurement, compound 4: 8.2 percentage points above; low and high end bracket the measured number.
By their numbers in this assay, from the lowest: compounds 3 and 4 (each within the scatter of the next); then compound 2; then compound 1.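

In this assay, cyclohexyl in place of 4-methylphenyl on a nitrogen on an aromatic ring gives a number 29.8 percentage points lower from compound 2 to compound 4 (beyond the scatter). The substituent on this nitrogen therefore matters with the 2-((2-aminophenyl)carbamoyl)ethenyl group as well, not only with the (2-aminophenyl)carbamoyl group carried by compound 1 and compound 3. This is also the first non-aromatic ring at this position, and it does not retain the effect seen with 4-methylphenyl; nothing at hand explains the fall.

The compounds shown do not separate the loss of the aromatic ring from the loss of the methyl group, a question that a plain phenyl on this nitrogen would address. Also open, on these data alone, is whether cyclohexyl gives a step of similar size on the (2-aminophenyl)carbamoyl parent, compound 1.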